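Methyl to Bromo Exchange on Two Related Cores

A few compounds are considered here, and "the series" means these few. Any claim that something is new, unique, unknown or untested is made for them only; others in the source may bear on it.

The measured compounds are:
compound 1 `COC(=O)[C@@]1(C)CC[C@@H]2C3=C1CC[C@@H](C)[C@]3(C)C[C@@H]1c3cc(C)ccc3N[C@H]21`, which in a functional assay on WiDr cells (Homo sapiens) for inhibition, read by sulforhodamine B assay, with a stated time of 48 h (on this read-out higher numbers stand for weaker inhibition of growth and lower numbers for stronger inhibition of growth), gives 32000 nM;
compound 2 `COC(=O)[C@@]1(C)CC[C@@H]2C3=C1CC[C@@H](C)[C@]3(C)C[C@@H]1c3cc(Br)ccc3N[C@H]21`, which in this assay gives 55000 nM;
compound 3 `COC(=O)[C@@]1(C)CC[C@@H]2C3=C1CC[C@@H](C)[C@]3(C)Cc1c2[nH]c2c(C)cccc12`, which in this assay gives 22000 nM.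

Compound 4 `COC(=O)[C@@]1(C)CC[C@@H]2C3=C1CC[C@@H](C)[C@]3(C)Cc1c2[nH]c2c(Br)cccc12` has not been measured.

Compounds 1 and 2 share one core. The change between them is bromo in place of methyl on an aromatic carbon, and it brought a 1.7-fold higher number from compound 1 to compound 2 (0.24 log units; within the scatter). Compound 3 carries a different core; how the core of compound 1 and the core of compound 3 differ is not broken down here. Compound 3 stands with the lowest of the three numbers, yet its gap to compound 1 lies within the scatter, so no order between those two can be read.

Compound 4 differs from compound 3 by bromo in place of methyl on an aromatic carbon. Within the data shown here, this is the same kind of change as the one from compound 1 to compound 2, though not the same: in compound 2 the entering group sits meta to a fused ring and para to a fused ring, whereas in compound 4 it sits ortho to a fused ring and meta to a fused ring.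

The expectation rests on a single earlier example. Because the earlier change gave a 1.7-fold higher number from compound 1 to compound 2 (0.24 log units; within the scatter), the step from compound 3 to compound 4 is expected to be a 1.5-fold higher number from compound 3 to compound 4 (0.16 log units; within the scatter), a small step in the same direction. Compound 4 is thus estimated at 32000 nM, with a likely range from 14000 nM to 75000 nM.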

Compound 4, concentration for 50% growth inhibition: 37000 nM
Compound 4: the middle estimate sits 1.2-fold (0.06 log units) below what was measured, within the range that was stated.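

In this assay, bromo in place of methyl on an aromatic carbon of the core of compound 3 gave a 1.7-fold higher number from compound 3 to compound 4 (0.23 log units; within the scatter). Set beside the earlier case, the exchange reads alike on both cores, and the two steps do not differ: the same change on two cores in this assay, a 1.7-fold higher number (0.24 log units; within the scatter) from compound 1 to compound 2 and a 1.7-fold higher number (0.23 log units; within the scatter) from compound 3 to compound 4, 1.0-fold (0.01 log units) apart, within the scatter of two such steps. This shows that in both cases the change left the number within the scatter, but since neither step stands clear of that scatter, the agreement shows no measurable effect of the exchange that was carried from one core to the other, and two cores are too few to predict the outcome on any further core in this series or to say why the steps agree.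

The compounds shown leave open how other groups on this aromatic carbon, such as chloro, methoxy, an amine or a carboxylic acid, would behave on either core, and whether any of them would give a step beyond the scatter. They also leave open what would follow from replacing the methyl ester common to all four compounds with a carboxylic acid or an amide.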